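Cyclopentyl for 4-chlorophenyl: expected cytotoxicity of compound 3

A few compounds are considered here, and "the series" means these few. Any claim that something is new, unique, unknown or untested is made for them only; others in the source may bear on it.

Two thioamide-linked compounds have been measured in an ADME assay on Huh-7 cells (Homo sapiens) for cytotoxicity; a higher number here means that more compound is tolerated, a lower number that less compound is tolerated. Compound 1 `O=C(NC(=S)n1ccc2c(OCCCCCOc3ccc(Cl)cc3)cccc21)c1ccccc1` gives 29500 nM, and compound 2 `O=C(NC(=S)N1CCc2c(OCCCCCOc3ccc(Cl)cc3)cccc21)c1ccc(Cl)cc1` gives 21700 nM. Compound 2 has the lowest of the two numbers, and its nearest neighbour is compound 1, whose number lies within the scatter of it. Compound 3 `O=C(NC(=S)N1CCc2c(OCCCCCOc3ccc(Cl)cc3)cccc21)C1CCCC1` differs from compound 2 in one place: cyclopentyl in place of 4-chlorophenyl on a carbonyl carbon. Within the data shown here, no measured step of this kind is known here, so the step from compound 2 to compound 3 is expected to stay within the scatter, with no clear direction, as a 1.2-fold higher number from compound 2 to compound 3 (0.06 log units; within the scatter). Compound 3 is therefore estimated at 25000 nM, within a range from 10000 nM to 60000 nM.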

Compound 3, half-maximal cytotoxic concentration: > 50000 nM
Compound 3: a limit, no number; the forecaster's own chance of this, stated with the estimate: 10%; at least 2.0-fold (0.30 log units) between middle value and limit.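

The group on this carbonyl carbon matters in this assay: cyclopentyl in place of 4-chlorophenyl gives an at least 2.3-fold higher number from compound 2 to compound 3 (0.36 log units; beyond the scatter), the only step shown that lies beyond the scatter. On these data alone, for compound 3 the result is a limit and not a number, so the full size of the step stays unknown: the limit of > 50000 nM in this assay, at which 1 of the 3 values shown sits.

The compounds shown do not separate the loss of the chlorine from the change of ring. As far as these compounds go, how a cyclohexyl or a tert-butyl group on this carbonyl carbon would compare also remains open.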